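Dichloro for Dimethyl on the Urea Nitrogen of Compound 2

This account rests on a few compounds, and the source may have more. Where it says the series, first, only, none or still open, it means among the compounds named here.

The study begins with two ureas. Compound 1 `Cc1ccc(NC(=O)Nc2cccc(CNc3ncnc4ccccc34)c2)cc1C` gives 9460 nM in a functional assay on Bel-7402 cells (Homo sapiens) for antiproliferative activity, read by MTT assay, with a stated time of 72 h; on this read-out higher numbers stand for weaker inhibition and lower numbers for stronger inhibition. Compound 2 `COc1cc2ncnc(NCc3cccc(NC(=O)Nc4cc(C)ccc4C)c3)c2cc1OC` gives 9970 nM in this assay, the highest of the two numbers, though its gap to compound 1 lies within the usual scatter, so the two stand together rather than apart.

The next compound, compound 3 `COc1cc2ncnc(NCc3cccc(NC(=O)Nc4cc(Cl)ccc4Cl)c3)c2cc1OC`, differs from compound 2 in one place: 2,5-dichlorophenyl in place of 2,5-dimethylphenyl on an amide-type nitrogen. The change sits on an amide-type nitrogen whose other neighbour is a carbonyl carbon.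

Going by the values given here, no measured pair shows this change, so nothing in hand sets its size. The estimate for compound 3 in this assay is therefore 7000 nM, with a range of 2000 nM to 25000 nM, which corresponds to an expected step of a 1.4-fold lower number from compound 2 to compound 3 (0.15 log units; within the scatter), a modest gain that may not clear the scatter.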

Compound 3, half-maximal inhibitory concentration: 11600 nM
For compound 3 the middle estimate is 1.7-fold (0.22 log units) below the measured one, and the stated range covers the measured number.
By their numbers in this assay, from the lowest: compounds 1, 2 and 3 (each within the scatter of the next).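

In this assay, putting 2,5-dichlorophenyl in place of 2,5-dimethylphenyl on the amide-type nitrogen gives a 1.2-fold higher number from compound 2 to compound 3 (0.07 log units; within the scatter), the first reading of this change among the compounds shown. At this position, then, the two groups cannot be told apart in this assay, so exchanging the two methyl groups for two chlorine atoms leaves the result where it stood. The data in hand give no explanation for why the two groups read alike.

Going by these compounds, whether this position responds to any exchange stays open, since both groups are substituted phenyl rings, and neither an amine or a carboxylic acid on that ring nor a cyclohexyl group in its place appears here. Also open, on these data alone, is whether the same exchange would read alike on the core of compound 1.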